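The source may hold more compounds than are shown below. What is called first, only, known or untested is meant among the compounds shown, and "the series" means these compounds.

Compound 1 `CC(=O)/C=C/c1cc(C)c(Oc2cc(Nc3ccc(C#N)cc3)c(N)cc2C(F)(F)F)c(C)c1`: > 8600 nM
Compound 2 `Cc1cc(/C=C/C#N)cc(C)c1Oc1cc(Nc2ccc(C#N)cc2)c(N)cc1C(F)(F)F`: 15000 nM

Among the measured compounds shown here, in an ADME assay on TZM cells (Homo sapiens) for cytotoxicity, read by XTT assay, with a stated time of 4 days (a lower number here means that less compound is tolerated, a higher number that more compound is tolerated), compound 2 gives 15000 nM, the only true number so far. For compound 1, > 8600 nM is a limit of the assay and not a number. For the measured compounds named here, the one measured step, a step that the limit leaves unreadable from compound 1 to compound 2, therefore offers no size to carry forward.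

Compound 3 `Cc1cc(C#N)cc(C)c1Oc1cc(Nc2ccc(C#N)cc2)c(N)cc1C(F)(F)F` differs from compound 2 in one place: cyano in place of 2-cyanoethenyl on an aromatic carbon. The 2-cyanoethenyl leaves and a cyano enters on the same aromatic carbon, meta to two methyl groups and para to a large group. Going by the values given here, no measured step bears directly on this change, so the value of compound 2, 15000 nM, is the sole anchor, and no step beyond the scatter is expected in either direction in this assay. The expected change is a 1.1-fold lower number from compound 2 to compound 3 (0.03 log units; within the scatter). For compound 3 the estimated value is 14000 nM, with an expected range from 6000 nM to 35000 nM.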

Compound 3, half-maximal cytotoxic concentration in the TZM assay: 13300 nM
Compound 3: middle estimate off by 1.1-fold (0.02 log units), on the high side; measured number inside the range.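

Among the compounds shown here, at this aromatic carbon, the first step that can be read in the TZM assay is a 1.1-fold lower number from compound 2 to compound 3 (0.05 log units; within the scatter), so putting cyano in place of 2-cyanoethenyl leaves the two compounds indistinguishable in how well the cells tolerate them. In a physicochemical assay for solubility, with a stated time of 4 h, at pH 2.0 (on this read-out higher numbers stand for higher solubility and lower numbers for lower solubility), the same change does separate the pair, with compound 3 the more soluble: the measured solubility of compound 2, 0.42 ug/mL, and of compound 3, 0.96 ug/mL, a 2.3-fold higher number (0.36 log units; beyond the scatter). In the physicochemical assay compound 2 gives 0.42 ug/mL and compound 3 gives 0.96 ug/mL. In the TZM assay compound 1 gives > 8600 nM, which is a limit of the assay and not a number, and the steps from it cannot be read.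

Going by these compounds, whether a different group on this aromatic carbon, such as an amine or a carboxylic acid, would shift either read-out remains open. A single pair also cannot tell whether the solubility step would recur when the same swap is made on another core.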